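Adding a Methoxy Group to the Core of Compound 2

The compounds below may be only part of what the source reports. "The series", "measured", "known", "first", "only" and "open" are said of these compounds alone.

Of the compounds shown here, two of a shared core have so far been measured in a functional assay on cells for positive allosteric modulation of metabotropic glutamate receptor 2 (Homo sapiens), read by fluorescence and calcium flux, with a stated time of 30 min; on this read-out higher numbers stand for an effect only at larger amounts of compound and lower numbers for an effect already at smaller amounts. Compound 1 `Brc1cccc2c1nnn2CC1CCC1` gives 20 nM, while compound 2 `Brc1cccc2c1nnn2CC1CC1` gives 70 nM. Among the measured compounds shown here, the one step between them, a 3.5-fold higher number from compound 1 to compound 2 (0.54 log units; beyond the scatter), exchanges cyclobutyl for cyclopropyl on a saturated chain carbon bound to an aromatic nitrogen. Compound 2 therefore stands at the highest of the two numbers, its nearest neighbour being compound 1 at a lower number beyond the scatter.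

Compound 3 `COc1cc(Br)c2nnn(CC3CC3)c2c1` differs from compound 2 in a single place: methoxy in place of hydrogen on an aromatic carbon. The methoxy enters on an aromatic carbon of the six-membered aromatic ring of carbon only, part of the fused system of two rings, meta to the bromo group. For the measured compounds named here, the only measured step alters the ring on the chain carbon and leaves this aromatic ring untouched, so no measured step bears on the change. With nothing to point either way, no step beyond the scatter is expected in this assay, though the range must be wide. Compound 3 is estimated at 70 nM, from 20 nM to 250 nM. This estimate implies no change at the digits printed from compound 2 to compound 3 (within the scatter), expected to remain within the scatter.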

Compound 3, half-maximal effective concentration: 730 nM
Beside the measured number, compound 3's estimate is 10-fold (1.02 log units) below it; measured number above the stated range.
By their numbers in this assay, from the lowest: compound 1; then compound 2; then compound 3.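

The earlier step left the aromatic ring of the shared core untouched, and this first change to that ring proves far from neutral: in this assay, methoxy in place of hydrogen on an aromatic carbon, meta to a bromo group, gives a 10-fold higher number from compound 2 to compound 3 (1.02 log units; beyond the scatter) and so moves the compound away from an effect at smaller amounts. This step, printed as large, outweighs the modest one on the other side of the molecule, a 3.5-fold higher number from compound 1 to compound 2 (0.54 log units; beyond the scatter), so this aromatic position responds at least as strongly to substitution as the ring on the chain carbon does to a change in size. No measurement is at hand that accounts for the loss.

Hydrogen and methoxy are the only two groups seen at this position, so it remains open whether any substituent here raises the number or whether this holds for methoxy alone, as a fluoro, methyl or hydroxy group on the same carbon could show. As far as these compounds go, it is equally open whether the same methoxy would cost as much on the cyclobutyl side chain of compound 1, or at another carbon of the same aromatic ring.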